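This account rests on a few compounds, and the source may have more. Where it says the series, first, only, none or still open, it means among the compounds named here.

Measured compounds in this set:

compound 1, `Cc1ccc(C(=O)N/N=C/c2ccc(Cl)cc2Cl)c(O)c1`: 291000 nM
compound 2, `Cc1ccc(C(=O)N/N=C/c2ccc(Cl)cc2)c(O)c1`: 116000 nM

In an ADME assay on cells (Mus musculus, strain BALB/C) for cytotoxicity, read by MTT assay, with a stated time of 24 h (a higher number here means that more compound is tolerated, a lower number that less compound is tolerated), compound 2 gives 116000 nM, the lowest of the two numbers. Its nearest neighbour is compound 1, which gives 291000 nM. The only measured step connecting them is a 2.5-fold lower number from compound 1 to compound 2 (0.40 log units; beyond the scatter), a modest change and the only direction of movement the series has shown so far.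

Compound 3, `Cc1ccc(C(=O)N/N=C/c2ccc(F)cc2)c(O)c1`, is not yet measured. It differs from compound 2 by fluoro in place of chloro on an aromatic carbon. Among the compounds with values here, no measured step exchanges one halogen for another; the one step that exists, a 2.5-fold lower number from compound 1 to compound 2 (0.40 log units; beyond the scatter), removes a chloro from the shared core altogether and therefore bears on the present change only loosely. With a single modest step as the whole of the evidence, and that step not of the same kind, the expectation for this assay is a small step downward from compound 2, or none beyond the scatter.

Compound 3 is accordingly expected to give about 90000 nM, with a plausible range from 40000 nM to 200000 nM, which amounts to an estimated step of a 1.3-fold lower number from compound 2 to compound 3 (0.11 log units; within the scatter).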

Compound 3, half-maximal cytotoxic concentration: 568000 nM
Beside the measured number, compound 3's estimate is 6.3-fold (0.80 log units) below it, outside the stated range (above it).
By their numbers in this assay, from the lowest: compound 2; then compounds 1 and 3 (each within the scatter of the next).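

In this assay the exchange of one halogen for another on an aromatic carbon, para to a large group, gives a 4.9-fold higher number from compound 2 to compound 3 (0.69 log units; beyond the scatter) and so brings the first upward movement from compound 2. The earlier step, a 2.5-fold lower number from compound 1 to compound 2 (0.40 log units; beyond the scatter) in the same assay, removes a chloro from a different place and could say nothing about this position; the new step shows that the number also responds to which halogen stands here, and that among the two halogens tried at this place, chloro in compound 2 goes with the lower number and fluoro in compound 3 with the higher. Nothing available explains why the number moves with this exchange, so the step stands as an observation only.

As far as these compounds go, two halogens give only two points at this position, so it remains open whether the higher number belongs to fluoro alone or would also appear with bromo, a methoxy group, a nitrile or an amine in the same place. From the compounds shown here alone, it also remains open whether the same exchange would move the number the same way on the core of compound 1, where a second chloro is present.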